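Swapping the pyrazole on compound 1 for a methylated isomer

A few compounds are considered here, and "the series" means these few. Any claim that something is new, unique, unknown or untested is made for them only; others in the source may bear on it.

Compound 1 `CNC(=O)N1CCCc2ccc(NC(=O)c3ccc(-c4cc[nH]n4)cc3)cc21` gives 550 nM in a functional assay on MV4-11 cells (Homo sapiens) for antiproliferative activity, with a stated time of 6 days; on this read-out higher numbers stand for weaker inhibition and lower numbers for stronger inhibition.
Compound 2 `CNC(=O)N1CCCc2ccc(NC(=O)c3cccc(-c4ccn(C)n4)c3)cc21` gives 980 nM in this assay.
Compound 3 `CNC(=O)N1CCCc2ccc(NC(=O)c3cccc(-c4cnn(C)c4)c3)cc21` gives 1040 nM in this assay.

Among these three, compound 1 has the lowest number, but its gaps to compound 2 and to compound 3 both lie within the usual scatter, so the three are best read as roughly equal. The new compound 4 `CNC(=O)N1CCCc2ccc(NC(=O)c3ccc(-c4cnn(C)c4)cc3)cc21` differs from compound 1 in one place: 1-methyl-1H-pyrazol-4-yl in place of 1H-pyrazol-3-yl on an aromatic carbon. For the measured compounds named here, only one measured step touches this kind of change: a 1.1-fold higher number from compound 2 to compound 3 (0.03 log units; within the scatter), which moved the attachment point of a methylated pyrazole and made no difference beyond the scatter. Going by the values given here, no measured pair isolates the loss of the pyrazole hydrogen-bond donor in favour of a methyl group, so that part of the change is an open question. Among the compounds with values here, with the one relevant step being flat, compound 4 is expected to sit close to compound 1, perhaps a little higher: an estimated 1.4-fold higher number from compound 1 to compound 4 (0.13 log units; within the scatter), giving an expected value of 750 nM for compound 4, with a range from 300 nM to 1900 nM.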

Compound 4, half-maximal inhibitory concentration: 730 nM
Estimate against measurement, compound 4: 1.0-fold (0.01 log units) above; the measured number falls inside the stated range.
By their numbers in this assay, from the lowest: compounds 1, 4, 2 and 3 (each within the scatter of the next).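

In this assay, replacing 1H-pyrazol-3-yl with 1-methyl-1H-pyrazol-4-yl on this aromatic carbon, para to a large group, gives a 1.3-fold higher number from compound 1 to compound 4 (0.12 log units; within the scatter). This is the first step shown that takes away the pyrazole's hydrogen-bond donor, going from 1 to 0, and the number stays within the scatter, so at this position the activity in this cell assay does not depend on that donor. No measurement here explains this flat result.

The step changes the methyl group and the attachment point together, so 1H-pyrazol-4-yl or 1-methyl-1H-pyrazol-3-yl at this position would be needed to separate the two. From the compounds shown here alone, it also remains open whether a quite different group here, such as a carboxylic acid or an aminomethyl group, would move the number beyond the scatter.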